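The source may hold more compounds than are shown below. What is called first, only, known or untested is meant among the compounds shown, and "the series" means these compounds.

Measured so far in a functional assay on KB cells (Homo sapiens) for cytotoxicity; on this read-out lower numbers stand for an effect already at smaller amounts and higher numbers for an effect only at larger amounts of compound:
- compound 1 `COC1=C(C)C(=O)/C(=C(O)/C=C/c2ccc(OC)cc2)C(=O)C1(C)C`: 3.6 ug/mL
- compound 2 `COC1=C(C)C(=O)/C(=C(O)/C=C/c2ccccc2C)C(=O)C1(C)C`: 4.1 ug/mL

Not yet measured: compound 3 `C=Cc1ccccc1/C=C/C(O)=C1/C(=O)C(C)=C(OC)C(C)(C)C1=O`.

Among the measured compounds shown here, only two numbers are available, and compound 2 at 4.1 ug/mL lies within the scatter of compound 1, its sole neighbour on this read-out. The next change leads to compound 3: vinyl in place of methyl on an aromatic carbon. In words, this is vinyl in place of methyl on an aromatic carbon, ortho to a large group, or 2-methylphenyl to 2-vinylphenyl.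

For the measured compounds named here, no measured step covers this exchange directly. Going by the values given here, the closest evidence is the single step available, a 1.1-fold higher number from compound 1 to compound 2 (0.06 log units; within the scatter), which replaces 4-methoxyphenyl with 2-methylphenyl on the same chain. That larger change in the aromatic group left this assay within the scatter, though one step is thin evidence. A step beyond the scatter is therefore not expected here, and the expected change is a 1.0-fold lower number from compound 2 to compound 3 (0.01 log units; within the scatter), with no direction favoured. The estimate for compound 3 is 4 ug/mL, with an expected range from 1.8 ug/mL to 9 ug/mL.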

Compound 3, concentration for half-maximal effect: 1.9 ug/mL
The estimate for compound 3 lay 2.1-fold (0.32 log units) above the measured number; the range from low to high includes it.
By their numbers in this assay, from the lowest: compounds 3, 1 and 2 (each within the scatter of the next, the first and the last beyond it).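

In this assay, vinyl in place of methyl on an aromatic carbon, ortho to a large group, gives a 2.2-fold lower number from compound 2 to compound 3 (0.33 log units; beyond the scatter); this modest step is the only one in the series that lies beyond the scatter. The earlier comparison of compound 1 with compound 2 gave no sign of sensitivity to the aromatic group, whereas this small exchange on the 2-methylphenyl group does register on the read-out, although 2-vinylphenyl in place of 4-methoxyphenyl still gives a 1.9-fold lower number from compound 1 to compound 3 (0.28 log units; within the scatter), which stays within the scatter. No measurement at hand bears on what lies behind the step, so it stands here as an observation only.

The compounds shown do not tell whether the step belongs to the double bond of vinyl or simply to the larger group, and an ethyl group on the same aromatic carbon, or a longer chain such as allyl, would be needed to separate the two. Also open, on these data alone, is whether vinyl gives a similar step when the same exchange is made on a different phenyl group or on another core.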